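Swapping the nitrophenyl for a furan: cytotoxicity outlook

This account rests on a few compounds, and the source may have more. Where it says the series, first, only, none or still open, it means among the compounds named here.

Measured compounds:
- Compound 1 `CCn1cc(C(=O)N2N=C(c3cc4ccccc4o3)CC2c2ccccc2Cl)c(=O)c2ccc(C)nc21` — > 178000 nM
- Compound 2 `CCn1cc(C(=O)N2N=C(c3cc4ccccc4o3)CC2c2ccccc2[N+](=O)[O-])c(=O)c2ccc(C)nc21` — > 85400 nM

In an ADME assay on Vero cells (Chlorocebus sabaeus) for cytotoxicity, read by MTT assay, with a stated time of 72 h (a lower number here means a stronger inhibitor, a higher number a weaker inhibitor), compound 1 gives only a limit, > 178000 nM. In this assay compound 2 likewise gives only a limit, > 85400 nM. For the measured compounds named here, compound 2 therefore stands at the limit of > 85400 nM in this assay, at which 1 of the 2 values shown sits, and the one other value shown sits at the limit of > 178000 nM in this assay, at which 1 of the 2 values shown sits; neither is a number. The step that the two limits leave unreadable from compound 1 to compound 2 cannot be sized for this reason.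

Compound 3 `CCn1cc(C(=O)N2N=C(c3cc4ccccc4o3)CC2c2ccco2)c(=O)c2ccc(C)nc21` has not yet been tested. It differs from compound 2 by furan-2-yl in place of 2-nitrophenyl on a saturated ring carbon. Going by the values given here, the only measured step, from compound 1 to compound 2, is unreadable and concerns a different change, so no measured step bears directly on the exchange of the 2-nitrophenyl for the furan-2-yl.

With both measured values at limits, compound 3 is expected to show the same picture: no reading beyond the scatter, with the step that the limit leaves unreadable from compound 2 to compound 3 expected to be small. The estimate for compound 3 in this assay is 150000 nM, within the range 30000 nM to 500000 nM, most likely reported again as a limit.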

Compound 3, half-maximal inhibitory concentration: > 185000 nM
Compound 3 gave a limit, no number (the forecaster's own chance of this, stated with the estimate: 80%); middle value at least 1.2-fold (0.09 log units) from the limit.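

In this assay compound 3 gives only a limit, > 185000 nM. Compound 1 and compound 2 also gave limits, so the steps among compound 1, compound 2 and compound 3 cannot be read. The compounds shown leave open whether 2-chlorophenyl, 2-nitrophenyl or furan-2-yl on this saturated ring carbon makes any difference to cytotoxicity.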